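The source may hold more compounds than are shown below. What is called first, only, known or untested is meant among the compounds shown, and "the series" means these compounds.

Measured so far in a functional assay on MV4-11 cells (Homo sapiens) for antiproliferative activity, read by luminescence, with a stated time of 72 h; a higher number here means a weaker inhibitor, a lower number a stronger inhibitor:
- compound 1 `C=CS(=O)(=O)NC/C=C/c1cc(OC)cc(O)c1C(=O)OC(C)C`: 4660 nM
- compound 2 `CCN(CC)C/C=C/C(=O)NC/C=C/c1cc(OC)cc(O)c1C(=O)OC(C)C`: > 10000 nM
- compound 3 `CCN(CC)C/C=C/C(=O)NC/C=C/c1cc(OCCc2ccc(F)cc2)cc(O)c1C(=O)OC(C)C`: 4040 nM

Compound 2 has no exact number on this scale. Its result of > 10000 nM is a limit of the assay, so compound 2 stands at the limit of > 10000 nM in this assay, at which 1 of the 3 values shown sits.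

For the measured compounds named here, the next molecule, compound 4 `C=CC(=O)NC/C=C/c1cc(OC)cc(O)c1C(=O)OC(C)C`, keeps the shared core and changes only one group: vinyl in place of 3-(diethylamino)prop-1-en-1-yl on a carbonyl carbon. In words, this puts vinyl in place of 3-(diethylamino)prop-1-en-1-yl on a carbonyl carbon.

Going by the values given here, the only measured step is an at least 2.4-fold lower number from compound 2 to compound 3 (0.39 log units; beyond the scatter). That change lies elsewhere in the molecule, so it shows that the result for compound 2 can be improved on but gives no direct size for the present swap. The closest guide is compound 1, which also carries a vinyl group, although on a sulfonyl rather than a carbonyl, and gives 4660 nM in this assay. On that basis, a modest move towards a lower number, meaning a stronger inhibitor, is expected, and the estimated change is an at least 2.0-fold lower number from compound 2 to compound 4 (0.30 log units; that floor lies within the scatter). The evidence is thin, so the expected range is wide. For compound 4 the estimated value is 5000 nM, with an expected range from 1800 nM to 10000 nM.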

Compound 4, half-maximal inhibitory concentration: > 10000 nM
Compound 4: a limit, no number; the forecaster's own chance of this, stated with the estimate: 20%; middle value at least 2.0-fold (0.30 log units) from the limit.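

In this assay compound 4 gives > 10000 nM, which is a limit of the assay and not a number. The step for vinyl in place of 3-(diethylamino)prop-1-en-1-yl on a carbonyl carbon cannot be read, as compound 2 and compound 4 both stand at the same limit, so shortening this group shows no measurable gain or loss: the limit of > 10000 nM in this assay, at which 2 of the 4 values shown sit.

The new information comes from the other comparison, where vinylcarbonyl in place of vinylsulfonyl on an amine nitrogen gives an at least 2.1-fold higher number from compound 1 to compound 4 (0.33 log units; beyond the scatter), so a vinyl group alone is not enough in this pair, and what joins it to the nitrogen makes a difference.

The compounds shown leave open how far below the limit or above it the true values of compound 2 and compound 4 lie, and whether the 4-fluorobenzyl change that separates compound 2 from compound 3 would also lower the number for the vinylcarbonyl compound. They also leave open what a chloromethyl group or a dimethylamino chain on the same carbonyl carbon would give.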